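Adding a Hydroxy Group on the Sugar Ring and Cytotoxicity

A few compounds are considered here, and "the series" means these few. Any claim that something is new, unique, unknown or untested is made for them only; others in the source may bear on it.

Compound 1 `Nc1nccn2c([C@@H]3O[C@H](CO)[C@@H](O)[C@H]3O)cnc12` gives > 64000 nM in an ADME assay on cells (Macrophage, Mus musculus) for cytotoxicity; on this read-out higher numbers stand for lower toxicity in this test and lower numbers for higher toxicity in this test.
Compound 2 `Nc1nccn2c([C@@H]3O[C@H](CO)C[C@H]3O)cnc12` gives > 64000 nM.
Compound 3 `Nc1ncnn2c([C@@H]3O[C@H](CO)C[C@H]3O)cc(-c3ccc(Cl)cc3)c12` gives 24000 nM.

The value of compound 1 is a limit of the assay, not a number. The value of compound 2 is likewise a limit. Within the data shown here, compound 3 gives the only number among the three. Compound 1 differs from compound 2 by hydroxy in place of hydrogen on a saturated ring carbon. The step that the two limits leave unreadable from compound 2 to compound 1 cannot be read because of the limit of > 64000 nM in this assay, at which 2 of the 3 values shown sit.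

Compound 4 `Nc1ncnn2c([C@@H]3O[C@H](CO)[C@@H](O)[C@H]3O)cc(-c3ccc(Cl)cc3)c12` has not been measured. It differs from compound 3 by hydroxy in place of hydrogen on a saturated ring carbon, the same change as from compound 2 to compound 1. The difference between the two cores, that of compound 2 and that of compound 3, is not broken down here.

For compound 4 a step of a 1.3-fold higher number from compound 3 to compound 4 (0.10 log units; within the scatter) is expected, which lies within the usual scatter, because the same change gave no readable step that the two limits leave unreadable from compound 2 to compound 1 and compound 3 gives a number at 24000 nM. Compound 4 is therefore expected to give about 30000 nM, between 12000 nM and 70000 nM, with a fair chance that only a limit is reported.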

Compound 4, half-maximal cytotoxic concentration: 5000 nM
For compound 4 the middle estimate is 6.0-fold (0.78 log units) above the measured one; the measured number lies below the stated range.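

In this assay, hydroxy in place of hydrogen on a saturated ring carbon gives a 4.8-fold lower number from compound 3 to compound 4 (0.68 log units; beyond the scatter), so on the core of compound 3 this change goes with higher toxicity in this test. On the core of compound 2 the same change cannot be read, because the values of compound 1 and compound 2 are both limits and not numbers: the limit of > 64000 nM in this assay, at which 2 of the 4 values shown sit. Among these compounds, the series therefore shows one readable step on one core, and it does not show whether the change behaves alike or differently on the two cores, since only a single pair gives a size.

The compounds shown leave open whether the lower number is tied to the hydroxy group itself or would also appear with an amine or a fluorine atom on that saturated ring carbon. They also leave open which of the differences between the two cores matters for the size of this step.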